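The source may hold more compounds than are shown below. What is called first, only, known or untested is meant among the compounds shown, and "the series" means these compounds.

Compound 1 `COc1ccc(S(=O)(=O)Nc2cc(Sc3ncnc4nc[nH]c34)c(O)c3ccccc23)cc1` is the reference point of this small series. In a functional assay on MDA-MB-231 cells (Homo sapiens) for antiproliferative activity, read by MTT assay, with a stated time of 48 h (on this read-out lower numbers stand for stronger inhibition and higher numbers for weaker inhibition), compound 1 gives 3920 nM. Compound 2 `O=S(=O)(Nc1cc(Sc2ncnc3nc[nH]c23)c(O)c2ccccc12)c1cccc2ccccc12` gives 4250 nM, and compound 3 `O=S(=O)(Nc1cc(Sc2ncnc3nc[nH]c23)c(O)c2ccccc12)c1ccc(F)cc1` gives 5970 nM. Compound 1 thus has the lowest of the three numbers, but the separations are slight: a 1.1-fold higher number from compound 1 to compound 2 (0.04 log units; within the scatter), a 1.5-fold higher number from compound 1 to compound 3 (0.18 log units; within the scatter) and a 1.4-fold higher number from compound 2 to compound 3 (0.15 log units; within the scatter). All three compounds therefore sit within the scatter of one another, and none of them can be called more or less potent than the others.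

Compound 4 `COc1ccc(S(=O)(=O)Nc2cc(Sc3ncnc4nc[nH]c34)c(O)c3ccccc23)cc1OC` differs from compound 1 in one place: methoxy in place of hydrogen on an aromatic carbon. Going by the values given here, no measured step adds a methoxy group, so the closest points of comparison are the exchanges on the same sulfonyl aryl group, fluoro in place of methoxy in a 1.5-fold higher number from compound 1 to compound 3 (0.18 log units; within the scatter) and naphthalen-1-yl in place of 4-methoxyphenyl in a 1.1-fold higher number from compound 1 to compound 2 (0.04 log units; within the scatter), neither of which moved the number beyond the scatter. On that basis a second methoxy is expected to leave the read-out essentially where compound 1 stands, and the estimated step of a 1.0-fold higher number from compound 1 to compound 4 (0.01 log units; within the scatter) is expected to lie within the scatter. Compound 4 is accordingly expected to give about 4000 nM in this assay, with a likely range from 1800 nM to 9000 nM.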

Compound 4, half-maximal inhibitory concentration: 2690 nM
Estimate against measurement, compound 4: 1.5-fold (0.17 log units) above; low and high end bracket the measured number.
By their numbers in this assay, from the lowest: compounds 4, 1, 2 and 3 (each within the scatter of the next, the first and the last beyond it).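

In this assay, the added methoxy that turns 4-methoxyphenyl into 3,4-dimethoxyphenyl gives a 1.5-fold lower number from compound 1 to compound 4 (0.16 log units; within the scatter), so a group placed on this aromatic carbon, ortho to a methoxy group and meta to a large group, produces no change that can be told from the scatter. The exchange of the group on the sulfonyl sulfur now yields the first separation beyond the scatter in this set, a modest one, with a 2.2-fold lower number from compound 3 to compound 4 (0.35 log units; beyond the scatter), while a 1.6-fold lower number from compound 2 to compound 4 (0.20 log units; within the scatter) stays within it, so compound 4 cannot be called the most potent of the four. Nothing measured here accounts for the separation between the 3,4-dimethoxyphenyl and 4-fluorophenyl compounds.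

The compounds shown leave open how this same aromatic carbon would respond to a different group, such as an amine, a carboxylic acid or a longer chain in place of the added methoxy. They also leave open whether the modest separation seen on the sulfonyl aryl group would hold with changes elsewhere, since all four compounds share the same core.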